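Series notes: methoxy in place of hydrogen, compound 4

This account rests on a few compounds, and the source may have more. Where it says the series, first, only, none or still open, it means among the compounds named here.

Compound 1 `Cc1ccccc1-n1nc(C)c2c1NC(=O)[C@H](C)S[C@@H]2c1ccc(Oc2ccccc2)cc1` gives 1300 nM in an assay on isolated protein for agonist activity at Bile acid receptor (Homo sapiens), read by AlphaScreen, with a stated time of 30 min; on this read-out lower numbers stand for an effect already at smaller amounts and higher numbers for an effect only at larger amounts of compound. Compound 2 `Cc1nn(-c2ccccc2C(C)C)c2c1[C@@H](c1ccc(Oc3ccccc3)cc1)S[C@@H](C)C(=O)N2` gives 1900 nM and differs from compound 1 by isopropyl in place of methyl on an aromatic carbon; the step of a 1.5-fold higher number from compound 1 to compound 2 (0.16 log units; within the scatter) lies within the scatter, so the two stand on a par. Compound 3 `COC(=O)c1cccc(-c2ccc([C@H]3S[C@@H](C)C(=O)Nc4c3c(C)nn4-c3ccccc3C)cc2)c1` is reported as "not active" (no number reported), without a number, after replacement of the phenoxy group by a methyl-ester-bearing phenyl. Compound 1 thus has the lowest of the two numbers, with compound 2 alongside it.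

Compound 4 `COc1cc([C@H]2S[C@@H](C)C(=O)Nc3c2c(C)nn3-c2ccccc2C)ccc1Oc1ccccc1` is not yet measured. It differs from compound 1 by methoxy in place of hydrogen on an aromatic carbon. Going by the values given here, no measured step touches this position: the step from compound 1 to compound 2 concerns a different aromatic carbon, and the change to compound 3 removes the phenoxy group entirely. There is no basis for a directed expectation; a step within the scatter, or a modest move towards a higher number, is the most that can be expected, written as a 1.4-fold higher number from compound 1 to compound 4 (0.14 log units; within the scatter). Compound 4 is therefore estimated at 1800 nM, with a range from 700 nM to 5000 nM.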

Compound 4, half-maximal effective concentration: 1900 nM
Compound 4: middle estimate off by 1.1-fold (0.02 log units), on the low side; the range from low to high includes it.
By their numbers in this assay, from the lowest: compounds 1, 2 and 4 (each within the scatter of the next).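

Methoxy ortho to a phenoxy group is accepted in this assay: the step of a 1.5-fold higher number from compound 1 to compound 4 (0.16 log units; within the scatter) leaves compound 4 on a par with compound 1. This is the first reading at this position, and it shows that 2 heavy atoms and 1 hydrogen-bond acceptor can enter here with no step beyond the scatter, whereas compound 2 had shown this only for isopropyl in place of methyl on a different aromatic carbon. No data at hand bear on what lies behind this result.

Open, from the compounds shown here alone, is whether the position also accepts an amine, a carboxylic acid or a longer chain such as butoxy in place of the hydrogen. Also open, going by these compounds, is whether methoxy on the other carbons of this ring reads the same.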